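This account rests on a few compounds, and the source may have more. Where it says the series, first, only, none or still open, it means among the compounds named here.

The measured compounds:
compound 1 `CC(C)(C)c1ccc(C(=O)N2CCC3(CC2)C(=O)N(CC(=O)N2CCC(CCO)CC2)CN3c2ccccc2)cc1` with 2600 nM
compound 2 `CC(C)(C)c1ccc(C(=O)N2CCC3(CC2)C(=O)N(CC(=O)NCN)CN3c2ccccc2)cc1` with 26500 nM
compound 3 `CC(C)(C)c1ccc(C(=O)N2CCC3(CC2)C(=O)N(CC(=O)NCCCCNS(C)(=O)=O)CN3c2ccccc2)cc1` with 4500 nM

In an assay on HEK293 cells for displacement of a labelled ligand from NPC1-like intracellular cholesterol transporter 1 (Homo sapiens) (on this read-out higher numbers stand for weaker inhibition and lower numbers for stronger inhibition), compound 3 stands second highest of the three numbers; its nearest neighbour is compound 1, from which it is separated by a 1.7-fold higher number from compound 1 to compound 3 (0.24 log units; within the scatter), while compound 2 lies furthest away, a 5.9-fold lower number from compound 2 to compound 3 (0.77 log units; beyond the scatter). Compound 4 `CCOC(=O)C1CCCN(C(=O)CN2CN(c3ccccc3)C3(CCN(C(=O)c4ccc(C(C)(C)C)cc4)CC3)C2=O)C1` has not yet been measured. It differs from compound 3 in one place: 3-(ethoxycarbonyl)piperidin-1-yl in place of (4-(methanesulfonamido)butyl)amino on a carbonyl carbon.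

For the measured compounds named here, no measured step covers exactly this exchange. The nearest comparison is the step from compound 1 to compound 3, a 1.7-fold higher number from compound 1 to compound 3 (0.24 log units; within the scatter), in which a piperidin-1-yl substituent on the same carbonyl carbon gave way to an open-chain amino substituent; the present step runs the other way, back to a piperidin-1-yl amide. The large step of a 10-fold higher number from compound 1 to compound 2 (1.01 log units; beyond the scatter) shows that a much smaller amino substituent at this carbonyl carbon weakens binding, but compound 4 carries a substantial ring rather than a small group. On this basis compound 4 is expected to show a small lowering of the number, a 1.5-fold lower number from compound 3 to compound 4 (0.18 log units; within the scatter), which may well fall within the scatter. The estimate for compound 4 is 3000 nM, with a range from 1200 nM to 8000 nM.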

Compound 4, half-maximal inhibitory concentration: 8200 nM
Compound 4: the middle estimate sits 2.7-fold (0.44 log units) below what was measured, outside the stated range (above it).
By their numbers in this assay, from the lowest: compounds 1, 3 and 4 (each within the scatter of the next, the first and the last beyond it); then compound 2.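

In this assay, a ring ester and an open-chain sulfonamide at this carbonyl carbon read alike (a 1.8-fold higher number from compound 3 to compound 4 (0.26 log units; within the scatter)), even though 3-(ethoxycarbonyl)piperidin-1-yl has 0 hydrogen-bond donors and (4-(methanesulfonamido)butyl)amino has 2. A piperidin-1-yl amide does not by itself set the reading, since the two that are shown differ beyond the scatter, with 3-(ethoxycarbonyl)piperidin-1-yl in place of 4-(2-hydroxyethyl)piperidin-1-yl (a 3.2-fold higher number from compound 1 to compound 4 (0.50 log units; beyond the scatter)), while the same ester-bearing ring still compares favourably with the small (aminomethyl)amino group (a 3.2-fold lower number from compound 2 to compound 4 (0.51 log units; beyond the scatter)). Nothing at hand accounts for these differences.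

The two piperidine substituents differ both in the group carried and in where it sits on the ring, so the compounds shown cannot separate these two changes. An unsubstituted piperidin-1-yl, a 4-(ethoxycarbonyl)piperidin-1-yl and a 3-(2-hydroxyethyl)piperidin-1-yl group would each help to divide them, and a free carboxylic acid in place of the ethyl ester would test whether the ester itself matters at this carbonyl carbon.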